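The source may hold more compounds than are shown below. What is called first, only, known or untested is meant among the compounds shown, and "the series" means these compounds.

Measured so far:
Compound 1, `C=CCn1c(=O)/c(=C\c2ccccc2OC)[nH]c(=O)/c1=C\c1ccccc1OC`: in a functional assay on HL-60 cells (Homo sapiens) for cytotoxicity, read by CCK-8 assay, with a stated time of 72 h (a higher number here means a weaker inhibitor, a lower number a stronger inhibitor), compound 1 gives 15700 nM.
Compound 2, `C=CCn1c(=O)/c(=C\c2ccccc2F)[nH]c(=O)/c1=C\c1ccccc1OC`: in this assay compound 2 gives 18500 nM.

Compound 2 has the highest of the two numbers measured, and its nearest neighbour is compound 1, the step being a 1.2-fold higher number from compound 1 to compound 2 (0.07 log units; within the scatter). On these two numbers the two compounds are indistinguishable.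

Compound 3, `C=CCn1c(=O)/c(=C\c2ccc(Cl)c(Cl)c2)[nH]c(=O)/c1=C\c1ccccc1OC`, has not been measured. Compared with compound 2 its change is 3,4-dichlorophenyl in place of 2-fluorophenyl on a double-bonded chain carbon bound to an aromatic carbon.

Among the measured compounds shown here, only one measured step touches the same position, the one from compound 1 to compound 2, and it exchanged one substituent on that ring for another without moving the number beyond the scatter, a 1.2-fold higher number from compound 1 to compound 2 (0.07 log units; within the scatter). For the measured compounds named here, no measured pair shows what a 3,4-dichlorophenyl does here, so the expectation rests on that single step alone and is correspondingly uncertain.

The step from compound 2 to compound 3 is therefore expected to be a 1.2-fold lower number from compound 2 to compound 3 (0.09 log units; within the scatter), that is, no change beyond the scatter. Compound 3 is estimated to give 15000 nM in this assay, within a range from 5000 nM to 45000 nM.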

Compound 3, half-maximal inhibitory concentration: "not active" (no number reported)
For compound 3 the study gives words and no number; there is nothing to compare the estimate with.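

Among the compounds shown here, compound 3 is reported in this assay only as "not active", without a number, so no step from compound 2 to compound 3 can be read. The compounds shown leave open how large a number compound 3 would have, and what a 3,4-dichlorophenyl does compared with a 2-fluorophenyl. Nothing shown here accounts for this result.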